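This account rests on a few compounds, and the source may have more. Where it says the series, first, only, none or still open, it means among the compounds named here.

For the measured compounds named here, in an in vitro ADME assay on microsomes from Gut (Homo sapiens) for metabolic stability, in the presence of a further agent that is not named here (a higher number here means faster removal of the compound, a lower number slower removal), compound 1 `COc1ccc(OC(F)(F)F)cc1Cn1c(C(=O)NCC2(CO)CC2)cc2cc(C#N)ccc21` gives 51 mL.min-1.g-1 and compound 2 `COc1ccc(C(F)(F)F)cc1Cn1c(C(=O)NCC2(CO)CC2)cc2cc(C#N)ccc21` gives 49 mL.min-1.g-1, so compound 2 stands within the scatter of its only measured neighbour. Compound 3 `COc1ccc(C(C)(C)C)cc1Cn1c(C(=O)NCC2(CO)CC2)cc2cc(C#N)ccc21` alters one group of compound 2: tert-butyl in place of trifluoromethyl on an aromatic carbon. Going by the values given here, the one measured step that bears on this is a 1.0-fold lower number from compound 1 to compound 2 (0.02 log units; within the scatter), which lies within the scatter. That step exchanged one fluorine-bearing group for another, whereas tert-butyl carries no fluorine, so it is only a weak guide. A small upward move is expected, a 1.5-fold higher number from compound 2 to compound 3 (0.18 log units; within the scatter). Compound 3 is estimated at 75 mL.min-1.g-1, with an expected range from 40 mL.min-1.g-1 to 140 mL.min-1.g-1.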

Compound 3, intrinsic clearance in microsomes: 26 mL.min-1.g-1
The estimate for compound 3 lay 2.9-fold (0.46 log units) above the measured number; measured number below the stated range.
By their numbers in this assay, from the lowest: compounds 3, 2 and 1 (each within the scatter of the next).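

On this aromatic carbon, para to a methoxy group, the series now includes a group without fluorine: tert-butyl gives a 1.9-fold lower number from compound 2 to compound 3 (0.28 log units; within the scatter) and, against trifluoromethoxy, a 2.0-fold lower number from compound 1 to compound 3 (0.29 log units; within the scatter) in this assay. Both steps lie within the scatter, so swapping fluorine for carbon-only tert-butyl here does not separate these compounds in this read-out. Nothing available explains these numbers. As far as these compounds go, whether an amine, a carboxylic acid or a plain hydrogen on this carbon would also stay within the scatter remains open.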